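Adding One Substituent to Compound 1

The source may report more compounds than this note shows. Statements on the series, on what has been measured and on what is new or still open speak of the compounds shown alone.

Compounds measured so far:
compound 1, `O=C(Nc1ccc(-c2noc(-c3cccc(NS(=O)(=O)c4ccccc4)c3)n2)c(Cl)c1)c1cccnc1`, > 10000 nM
compound 2, `CC(=O)Nc1ccc(S(=O)(=O)Nc2cccc(-c3nc(-c4ccc(NC(=O)c5cccnc5)c(Cl)c4)no3)c2)cc1`, 4500 nM

In a functional assay on MDA-MB-231 cells (Homo sapiens) for antiproliferative activity, read by MTT assay, with a stated time of 72 h (a higher number here means a weaker inhibitor, a lower number a stronger inhibitor), compound 1 yields only a limit, > 10000 nM (the limit of > 10000 nM in this assay, at which 1 of the 2 values shown sits). For the measured compounds named here, compound 2 gives a measurable value, 4500 nM, and the two compounds differ in more than one place, so no single step between them can be stated.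

Compound 3, `O=C(Nc1ccc(-c2noc(-c3cccc(NS(=O)(=O)c4ccc(NC(=O)N5CCOCC5)cc4)c3)n2)c(Cl)c1)c1cccnc1`, differs from compound 1 in one place: ((morpholin-4-yl)carbonyl)amino in place of hydrogen on an aromatic carbon. Going by the values given here, no measured step of this kind exists here, so the expectation rests on compound 2, whose substituted ring gave a number rather than a limit. Compound 3 is expected to move into the measurable range, a step estimated at an at least 2.5-fold lower number from compound 1 to compound 3 (0.39 log units; beyond the scatter). Compound 3 is expected to give about 4000 nM, between 1500 nM and 10000 nM.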

Compound 3, half-maximal inhibitory concentration: > 10000 nM
Compound 3: no number, only a limit; the forecaster's own chance of this, stated with the estimate: 35%; at least 2.5-fold (0.39 log units) between middle value and limit.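

In this assay, compound 1 and compound 3 each give only a limit, so no step between them can be read: the limit of > 10000 nM in this assay, at which 2 of the 3 values shown sit.

The compounds shown leave open whether ((morpholin-4-yl)carbonyl)amino in place of hydrogen changes the activity of compound 1 at all.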